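This account rests on a few compounds, and the source may have more. Where it says the series, first, only, none or still open, it means among the compounds named here.

Measured so far in a functional assay on ZR-75-1 cells (Homo sapiens) for inhibition, read by sulforhodamine B assay; a higher number here means a weaker inhibitor of growth, a lower number a stronger inhibitor of growth:
- Compound 1 `c1ccc(-c2ccc(-c3ccc(-c4nc5ccccc5[nH]4)cc3)cc2)cc1`: 100000 nM
- Compound 2 `Oc1cccc2[nH]c(-c3ccc(-c4ccc(-c5ccccc5)cc4)cc3)nc12`: 35600 nM

The number for compound 1 is the higher of the two, which makes it the weaker growth inhibitor of this pair. Among the compounds with values here, only one measured step starts from it: a 2.8-fold lower number from compound 1 to compound 2 (0.45 log units; beyond the scatter), with hydroxy in place of hydrogen on an aromatic carbon.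

Compound 3 `Cc1ccc2[nH]c(-c3ccc(-c4ccc(-c5ccccc5)cc4)cc3)nc2c1` has not yet been measured. Its difference from compound 1 is methyl in place of hydrogen on an aromatic carbon, so it carries methyl in place of hydrogen on an aromatic carbon. The change falls on the same kind of atom as in the measured step, but the entering group is another one, so that single step is only a loose guide. On the strength of a 2.8-fold lower number from compound 1 to compound 2 (0.45 log units; beyond the scatter), a modest move towards a lower number in this assay is expected, of similar size or smaller, and a result within the scatter would be no surprise. The expected step is a 1.8-fold lower number from compound 1 to compound 3 (0.26 log units; within the scatter). For compound 3 the estimated value is 55000 nM, with an expected range from 25000 nM to 100000 nM.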

Compound 3, concentration for 50% growth inhibition: 27400 nM
The estimate for compound 3 lay 2.0-fold (0.30 log units) above the measured number; low and high end bracket the measured number.
By their numbers in this assay, from the lowest: compounds 3 and 2 (each within the scatter of the next); then compound 1.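

In this assay, methyl on an aromatic carbon of the six-membered aromatic ring of carbon only, meta to a fused ring and para to a fused ring, gives a 3.6-fold lower number from compound 1 to compound 3 (0.56 log units; beyond the scatter). Within the data shown here, until now, the only measured change on such a carbon was hydroxy, with a 2.8-fold lower number from compound 1 to compound 2 (0.45 log units; beyond the scatter); the new step shows that a lower number does not require hydroxy, since methyl, which counts no hydrogen-bond donors and no hydrogen-bond acceptors, also moves the number beyond the scatter. Nothing at hand explains why either group lowers the number.

The compounds shown leave open whether an amine, a carboxylic acid or a longer chain such as ethyl on this same carbon would lower the number further, leave it unchanged or raise it. They also leave open whether methyl would give a similar step on the other aromatic carbons of this ring, as a single substitution at one place cannot show how the effect varies around the ring.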